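This account rests on a few compounds, and the source may have more. Where it says the series, first, only, none or still open, it means among the compounds named here.

Compound 1 `NC(=O)N1CCN(C(=S)SCc2cn(Cc3ccccc3F)nn2)CC1`: 43100 nM
Compound 2 `O=C(NC1CCCCC1)N1CCN(C(=S)SCc2cn(Cc3ccccc3F)nn2)CC1`: 84900 nM
Compound 3 `NC(=O)N1CCN(C(=S)SCc2cn(Cc3ccc(F)cc3)nn2)CC1`: 62700 nM

All three were tested in a functional assay on EC9706 cells (Homo sapiens) for cytotoxicity, read by MTT assay, with a stated time of 72 h; on this read-out lower numbers stand for stronger inhibition and higher numbers for weaker inhibition. Compound 3 gives 62700 nM, a number that sits between those of compound 1 and compound 2, all three within the usual scatter of one another. Compound 4 `CC(C)NC(=O)N1CCN(C(=S)SCc2cn(Cc3ccc(F)cc3)nn2)CC1` differs from compound 3 by isopropyl in place of hydrogen on an amide-type nitrogen. Going by the values given here, the only measured step of the same kind, a 2.0-fold higher number from compound 1 to compound 2 (0.29 log units; within the scatter), stayed within the scatter; the other, a 1.5-fold higher number from compound 1 to compound 3 (0.16 log units; within the scatter), concerns a different place and adds nothing here. A step of that small size, if any, is therefore expected in this assay, leaning toward a higher number. Compound 4 is expected to give about 80000 nM, with a range from 32000 nM to 200000 nM. The estimated step for compound 4 is a 1.3-fold higher number from compound 3 to compound 4 (0.11 log units; within the scatter).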

Compound 4, half-maximal inhibitory concentration: 12200 nM
The estimate for compound 4 lay 6.6-fold (0.82 log units) above the measured number; measured number outside the range, below it.
By their numbers in this assay, from the lowest: compound 4; then compounds 1, 3 and 2 (each within the scatter of the next).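

On the amide-type nitrogen, isopropyl in place of hydrogen moves the number beyond the scatter in this assay, with a 5.1-fold lower number from compound 3 to compound 4 (0.71 log units; beyond the scatter). The cyclohexyl step on the same nitrogen, a 2.0-fold higher number from compound 1 to compound 2 (0.29 log units; within the scatter), stayed within the scatter, so a substituent here does not always leave the number in place, and the direction differs between these two steps. No measurement here bears on why the number falls. Going by these compounds, it remains open how an ethyl group or a longer butyl chain on this nitrogen would read, and whether isopropyl gives a similar step alongside the 2-fluorophenyl group.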